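A few compounds are considered here, and "the series" means these few. Any claim that something is new, unique, unknown or untested is made for them only; others in the source may bear on it.

In a functional assay on MGC-803 cells (Homo sapiens) for inhibition, read by MTT assay, with a stated time of 48 h (on this read-out lower numbers stand for stronger inhibition and higher numbers for weaker inhibition), three amides sharing one core have been measured: compound 1 `COc1ccc(CN(C(=O)C=C(C)C)c2cc(OC)c(OC)c(OC)c2)cc1O` gives 320 nM, compound 2 `CCC/C=C/C(=O)N(Cc1ccc(OC)c(O)c1)c1cc(OC)c(OC)c(OC)c1` gives 70 nM, and compound 3 `C/C=C/C(=O)N(Cc1ccc(OC)c(O)c1)c1cc(OC)c(OC)c(OC)c1` gives 27 nM, the lowest number of the three. Compound 4 `COc1ccc(CN(C(=O)C[Se]C#N)c2cc(OC)c(OC)c(OC)c2)cc1O` keeps that core but swaps the group on the carbonyl carbon: a group of 4 heavy atoms (2 carbon, 1 nitrogen, 1 selenium; no ring) in place of a group of 3 heavy atoms (3 carbon; no ring), on a carbonyl carbon. The measured steps all change this same group: a 12-fold lower number from compound 1 to compound 3 (1.07 log units; beyond the scatter), a 4.6-fold lower number from compound 1 to compound 2 (0.66 log units; beyond the scatter) and a 2.6-fold lower number from compound 2 to compound 3 (0.41 log units; beyond the scatter). They range from modest to large, so the group matters, but none of them brings in selenium. Compound 3, at 27 nM, already lies lowest, so a modest rise is the likelier outcome. The expected change is a 3.0-fold higher number from compound 3 to compound 4 (0.47 log units; beyond the scatter). The estimated value for compound 4 is 80 nM, within a range of 15 nM to 400 nM.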

Compound 4, half-maximal inhibitory concentration: 270 nM
The estimate for compound 4 lay 3.4-fold (0.53 log units) below the measured number; low and high end bracket the measured number.
By their numbers in this assay, from the lowest: compound 3; then compound 2; then compounds 4 and 1 (each within the scatter of the next).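

In this assay, this position also accepts a group that is not a plain carbon chain, the one holding selenium and a nitrile, but that group gives weaker inhibition than the two unbranched chains: a 10-fold higher number from compound 3 to compound 4 (1.00 log units; beyond the scatter) and a 3.9-fold higher number from compound 2 to compound 4 (0.59 log units; beyond the scatter). Against the branched 2-methylprop-1-en-1-yl group the step is a 1.2-fold lower number from compound 1 to compound 4 (0.07 log units; within the scatter), so those two groups cannot be told apart here. No measurement shown explains these differences. On these data alone, it remains open whether selenium or the nitrile drives the loss, and how a sulfur atom in place of selenium or a saturated propyl chain would read in this assay.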